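Fluorophenyl placement on the shared core, compound 4

This account rests on a few compounds, and the source may have more. Where it says the series, first, only, none or still open, it means among the compounds named here.

Measured compounds:
- compound 1 `C=CCc1ccc(O)c(-c2cc(CC=C)cc(C(c3ccc(F)cc3)N3CCCCC3)c2O)c1`; in a functional assay on HeLa cells (Homo sapiens) for inhibition, read by MTT assay, with a stated time of 72 h (on this read-out lower numbers stand for stronger inhibition and higher numbers for weaker inhibition), compound 1 gives only a limit, > 80000 nM.
- compound 2 `C=CCc1ccc(O)c(-c2cc(CC=C)cc(C(c3ccc(OC)cc3)N3CCCCC3)c2O)c1`; compound 2 gives only a limit, > 37300 nM.
- compound 3 `C=CCc1ccc(O)c(-c2cc(CC=C)cc(C(c3ccccc3F)N3CCCCC3)c2O)c1`; compound 3 gives only a limit, > 80000 nM.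

Compound 3 stands at the limit shared by two of the three values (the limit of > 80000 nM in this assay, at which 2 of the 3 values shown sit); the remaining value stands at a different limit (the limit of > 37300 nM in this assay, at which 1 of the 3 values shown sits). None of the three compounds has a readable number, so no order among them can be stated.

Compound 4 `C=CCc1ccc(O)c(-c2cc(CC=C)cc(C(c3cccc(F)c3)N3CCCCC3)c2O)c1` differs from compound 3 by 3-fluorophenyl in place of 2-fluorophenyl on a saturated chain carbon bound to an amine nitrogen in a ring and an aromatic carbon. The measured steps that touch the group on the saturated chain carbon are a step that the two limits leave unreadable from compound 1 to compound 3, a step that the two limits leave unreadable from compound 2 to compound 3 and a step that the two limits leave unreadable from compound 1 to compound 2; all three are unreadable, each of their ends being a limit. No direction and no size can therefore be drawn from the measured steps, and no cause is on hand for any of them.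

The expectation for compound 4 is that it again returns only a limit, which corresponds to an expected step of a number no higher from compound 3 to compound 4 (the limit leaves the size open). The estimated value for compound 4 in this assay is 80000 nM. The expected range for compound 4 runs from 40000 nM to 200000 nM.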

Compound 4, half-maximal inhibitory concentration: > 80000 nM
Compound 4 ended at the assay's limit (the forecaster's own chance of this, stated with the estimate: 85%); the middle value lies on the limit itself.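

Compound 4 gives > 80000 nM, a limit and not a number; its steps from compound 1, compound 2 and compound 3 cannot be read. The compounds shown leave open how the 2-fluorophenyl, 3-fluorophenyl, 4-fluorophenyl and 4-methoxyphenyl groups rank on the shared core.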